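Enlarging the urea end of a brain enzyme inhibitor

The source may report more compounds than this note shows. Statements on the series, on what has been measured and on what is new or still open speak of the compounds shown alone.

Of the compounds shown here, three sharing one core have been measured in an assay on microsomes from brain for inhibition of Fatty-acid amide hydrolase 1 (Rattus norvegicus), read by fluorescence and HPLC, with a stated time of 45 min; on this read-out lower numbers stand for stronger inhibition and higher numbers for weaker inhibition. Compound 1 `COCC(=O)Nc1ccc2c(cnn2CC(=O)COc2ccc(Oc3ccccc3)cc2)c1` gives 6300 nM, compound 2 `COC(=O)Nc1ccc2c(cnn2CC(=O)COc2ccc(Oc3ccccc3)cc2)c1` gives 4000 nM, and compound 3 `CCNC(=O)Nc1ccc2c(cnn2CC(=O)COc2ccc(Oc3ccccc3)cc2)c1` gives 1600 nM, the lowest of the three. The step of a 3.9-fold lower number from compound 1 to compound 3 (0.60 log units; beyond the scatter) and the step of a 2.5-fold lower number from compound 2 to compound 3 (0.40 log units; beyond the scatter) both lie beyond the scatter, so compound 3 is the strongest measured inhibitor. Compound 4 `O=C(COc1ccc(Oc2ccccc2)cc1)Cn1ncc2cc(NC(=O)Nc3ccccc3)ccc21` differs from compound 3 by phenyl in place of ethyl on an amide-type nitrogen. Going by the values given here, no measured step swaps an alkyl for an aromatic group, so none bears directly on this change; the measured steps only show that variation at this end of the molecule shifts this assay by modest amounts. Compound 4 is therefore expected to move a 2.0-fold lower number from compound 3 to compound 4 (0.30 log units; within the scatter), giving an estimated 800 nM with a range from 250 nM to 3000 nM.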

Compound 4, half-maximal inhibitory concentration: 6000 nM
The estimate for compound 4 lay 7.5-fold (0.88 log units) below the measured number; measured number outside the range, above it.
By their numbers in this assay, from the lowest: compound 3; then compounds 2, 4 and 1 (each within the scatter of the next).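

On this amide-type nitrogen, a larger group does not extend the gain seen with ethyl: in this assay there is a 3.8-fold higher number from compound 3 to compound 4 (0.57 log units; beyond the scatter) and compound 3 remains the strongest inhibitor shown. The anilino group brings no clear separation from the methoxy or methoxymethyl groups, with a 1.5-fold higher number from compound 2 to compound 4 (0.18 log units; within the scatter) and with a 1.1-fold lower number from compound 1 to compound 4 (0.02 log units; within the scatter) in the same assay. Adding a phenyl here therefore gives up the advantage of the ethyl urea.

On these data alone, whether a propyl or longer chain, or a non-aromatic cyclohexyl ring, would keep that advantage remains open. No measurement shown here gives a reason for the step.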